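Replacing the pyridinyl ether with fluoro: expected half-life

A few compounds are considered here, and "the series" means these few. Any claim that something is new, unique, unknown or untested is made for them only; others in the source may bear on it.

Compound 1, `C=CC(=O)NCc1coc(-c2c(N)ncnc2Nc2ccc(Oc3ccccc3)c(Cl)c2)n1`: in an in vitro ADME assay on microsomes from liver (Homo sapiens) for metabolic stability, tested at 5 uM (on this read-out lower numbers stand for a shorter-lived compound and higher numbers for a longer-lived compound), compound 1 reports only a limit, > 1.66 h.
Compound 2, `C=CC(=O)NCc1coc(-c2c(N)ncnc2Nc2ccc(Oc3cccc(F)c3)c(Cl)c2)n1`: compound 2 likewise reports a limit, > 1.66 h.
Compound 3, `C=CC(=O)NCc1coc(-c2c(N)ncnc2Nc2ccc(Oc3ccccn3)c(Cl)c2)n1`: compound 3 gives 0.65 h.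

Among the compounds with values here, compound 3 thus holds the only actual number among the three; the other two values are limits (the limit of > 1.66 h in this assay, at which 2 of the 3 values shown sit). Compound 4, `C=CC(=O)NCc1coc(-c2c(N)ncnc2Nc2ccc(F)c(Cl)c2)n1`, differs from compound 3 by fluoro in place of (pyridin-2-yl)oxy on an aromatic carbon. Within the data shown here, no measured step removes the aryl ether outright. The nearest are an at least 2.5-fold lower number from compound 1 to compound 3 (0.40 log units; beyond the scatter) and an at least 2.5-fold lower number from compound 2 to compound 3 (0.40 log units; beyond the scatter), while the step from compound 1 to compound 2 cannot be read from two limits. Taking the pyridin-2-yloxy away is therefore expected to move compound 4 upward in this assay, the size uncertain. Compound 4 is estimated at 1.3 h (range 0.5 h to 3 h), an expected 2.0-fold higher number from compound 3 to compound 4 (0.30 log units; within the scatter).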

Compound 4, half-life: 0.267 h
For compound 4 the middle estimate is 4.9-fold (0.69 log units) above the measured one, and the stated range ends above it.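

In this assay, removing the aryl ether outright gives a 2.4-fold lower number from compound 3 to compound 4 (0.39 log units; beyond the scatter), so the lower number seen with the pyridin-2-yl ether did not mean that less of the ether favours a longer half-life. Against the other two ethers, fluoro gives an at least 6.2-fold lower number from compound 1 to compound 4 (0.79 log units; beyond the scatter) and an at least 6.2-fold lower number from compound 2 to compound 4 (0.79 log units; beyond the scatter), which places fluoro lowest of the groups seen at this position. Both of these steps are bounds rather than sizes: the limit of > 1.66 h in this assay, at which 2 of the 4 values shown sit.

On these data alone, whether a methoxy group or an amine at this position would track fluoro or the aryl ethers stays open. So does how far the true half-lives of compound 1 and compound 2 extend past their limits.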